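Pyrazole amide series: cytotoxicity on fibroblasts, compound 4 pending

A few compounds are considered here, and "the series" means these few. Any claim that something is new, unique, unknown or untested is made for them only; others in the source may bear on it.

Measured so far:
- compound 1 `CO[C@H]1CC[C@H](NC(=O)c2n[nH]cc2NC(=O)c2ncoc2-c2ccccc2)CC1`: 28000 nM
- compound 2 `COc1cccc(OC)c1C(=O)Nc1c[nH]nc1C(=O)N[C@H]1CC[C@H](O)CC1`: 34000 nM
- compound 3 `CO[C@H]1CC[C@H](NC(=O)c2n[nH]cc2NC(=O)c2ccc(N3CCN(C)CC3)cc2)CC1`: 20000 nM

All three numbers come from an ADME assay on MRC5 cells (Homo sapiens) for inhibition, with a stated time of 72 h; on this read-out lower numbers stand for an effect already at smaller amounts and higher numbers for an effect only at larger amounts of compound. In this assay compound 1 gives 28000 nM, compound 2 gives 34000 nM and compound 3 gives 20000 nM. Compound 2 holds the highest number of the three, but its gap to compound 1 and its gap to compound 3 both lie within the scatter, so no order among the three can be read from these data.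

Compound 4 `COC(=O)c1n[nH]cc1NC(=O)c1c(OC)cccc1OC` is the next compound to be measured in this assay. It keeps the core of compound 2 and changes one place: methoxy in place of (4-hydroxycyclohexyl)amino on a carbonyl carbon. Within the data shown here, no step between two measured compounds isolates this change, so the expectation rests on the level of the series alone, which sits uniformly at high concentrations. The expected step from compound 2 to compound 4 is a 1.2-fold higher number from compound 2 to compound 4 (0.07 log units; within the scatter), that is, no movement beyond the scatter. For compound 4 the estimate in this assay is 40000 nM, with a range from 15000 nM to 100000 nM; a limit instead of a number is a real possibility.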

Compound 4, half-maximal effective concentration: > 50000 nM
Compound 4 was reported as a limit; the forecaster's own chance of this, stated with the estimate: 30%; at least 1.2-fold (0.09 log units) between middle value and limit.
By their numbers in this assay, from the lowest: compounds 3, 1 and 2 (each within the scatter of the next). At a limit, above all of these: compound 4.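

Methoxy in place of (4-hydroxycyclohexyl)amino on a carbonyl carbon gives the only readable step at this place in this assay, an at least 1.4-fold higher number from compound 2 to compound 4 (0.16 log units; that floor lies within the scatter). The floor of this step lies within the scatter, so the pair shows no clear shift, but it does show that the series stays at high concentrations in this pair without the six-membered ring and its two stereocentres. Compound 4 is reported as a limit, so the full size of the step cannot be read: the limit of > 50000 nM in this assay, at which 1 of the 4 values shown sits.

On these data alone, it remains open how a carboxylic acid or a short-chain alkylamine on this carbonyl carbon would read in this assay. As far as these compounds go, it is also open whether the same change would give a similar result with the other acyl groups of compound 1 and compound 3.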